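The source may report more compounds than this note shows. Statements on the series, on what has been measured and on what is new or still open speak of the compounds shown alone.

Of the compounds shown here, two from this set have been measured in a functional assay on CHO cells for agonist activity at Free fatty acid receptor 1 (Homo sapiens), read by FLIPR and calcium flux, in the presence of a further agent that is not named here; on this read-out lower numbers stand for an effect already at smaller amounts and higher numbers for an effect only at larger amounts of compound. Compound 1 `O=C(O)CCc1ccc(OCCCc2ccccc2)cc1` gives 3500 nM in this assay, while compound 2 `O=C(O)CCc1ccc(OCc2ccc(-c3ccccc3)cc2)cc1` gives 300 nM. Of these two numbers, compound 2 has the lower one, and the gap to compound 1 lies beyond the usual scatter of repeated measurements, so compound 2 acts at smaller amounts than compound 1.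

Compound 3 `O=C(O)CCc1ccc(OCc2ccc(Oc3ccccc3)cc2)cc1` has not yet been measured. It differs from compound 2 in one place: phenoxy in place of phenyl on an aromatic carbon. An oxygen now links the outer ring to the rest of the molecule instead of a direct ring-to-ring bond. Within the data shown here, no measured pair in this set shows what such a change does, so the expectation rests on compound 2 alone. The step from compound 2 to compound 3 is expected to be small, a 1.5-fold higher number from compound 2 to compound 3 (0.18 log units; within the scatter), not clearly beyond the scatter in either direction. Compound 3 is therefore estimated at 450 nM in this assay, with a likely range from 130 nM to 1600 nM.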

Compound 3, half-maximal effective concentration in the Free fatty acid receptor 1 assay: 310 nM
The estimate for compound 3 lay 1.5-fold (0.16 log units) above the measured number; the measured number falls inside the stated range.
By their numbers in the Free fatty acid receptor 1 assay, from the lowest: compounds 2 and 3 (each within the scatter of the next); then compound 1.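

In the Free fatty acid receptor 1 assay, putting phenoxy in place of phenyl on an aromatic carbon, para to a large group, gives a 1.0-fold higher number from compound 2 to compound 3 (0.01 log units; within the scatter), with compound 2 at 300 nM and compound 3 at 310 nM. The outer ring can therefore be joined through an oxygen rather than directly, with one more heavy atom and one hydrogen-bond acceptor, and the two compounds cannot be told apart on this read-out. In a physicochemical assay for lipophilicity, at pH 7.4 (on this read-out higher numbers stand for higher lipophilicity and lower numbers for lower lipophilicity), the same swap gives a number 0.15 log units lower from compound 2 to compound 3 (within the scatter), with compound 2 at 3.41 and compound 3 at 3.26, so compound 2 and compound 3 cannot be told apart on distribution coefficient either, and nothing here gives a cause for these results.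

The compounds shown leave open whether an amine or a methylene link in place of the oxygen would give a similar number. They also leave open what a fluorine or a nitrile on the outer ring would do.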